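The compounds below may be only part of what the source reports. "The series", "measured", "known", "first", "only" and "open" are said of these compounds alone.

Compound 1 `NC(=O)c1c(NC(=O)c2ccccc2Cl)sc2c1CCNC2` is one of three compounds built on a shared core and examined in a functional assay on HeLa cells (Homo sapiens) for antiproliferative activity, with a stated time of 24 h; a higher number here means a weaker inhibitor, a lower number a stronger inhibitor. In this assay compound 1 gives 45000 nM, the larger of the two numbers obtained, though the gap to its nearest neighbour, compound 2 `NC(=O)c1c(NC(=O)c2ccccc2Cl)sc2c1CCN(Cc1c(Cl)cccc1Cl)C2`, which gives 28800 nM, lies within the scatter. For compound 3 `NC(=O)c1c(NC(=O)c2ccc(C(F)(F)F)cc2)sc2c1CCN(Cc1ccc(Cl)cc1Cl)C2` this assay reports only a limit, > 50000 nM. Among the compounds with values here, the single measured step, a 1.6-fold lower number from compound 1 to compound 2 (0.19 log units; within the scatter), shows that placing a 2,6-dichlorobenzyl group on the ring amine nitrogen left the number within the scatter. Compound 4 `NC(=O)c1c(NC(=O)c2ccccc2Cl)sc2c1CCN(C(=S)Nc1ccccc1Br)C2` is changed at the same place: a group of 10 heavy atoms (7 carbon, 1 nitrogen, 1 sulfur, 1 bromine; one six-membered aromatic ring of carbon only) in place of a hydrogen atom, on an amine nitrogen in a ring. Because a 1.6-fold lower number from compound 1 to compound 2 (0.19 log units; within the scatter) stayed within the scatter, no step beyond the scatter is expected in this assay from compound 1 to compound 4 either, and a limit rather than a number remains possible in view of the limit of > 50000 nM in this assay, at which 1 of the 3 values shown sits. Compound 4 is therefore estimated at 38000 nM, within a range of 14000 nM to 100000 nM. The step this implies, a 1.2-fold lower number from compound 1 to compound 4 (0.07 log units; within the scatter), is expected to remain within the scatter.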

Compound 4, half-maximal inhibitory concentration: 24600 nM
Compound 4: middle estimate off by 1.5-fold (0.19 log units), on the high side, and the stated range covers the measured number.
By their numbers in this assay, from the lowest: compounds 4, 2 and 1 (each within the scatter of the next). At a limit, above all of these: compound 3.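

In this assay, a second group on the amine nitrogen in a ring, built quite differently from the first, again leaves the number within the scatter, with a 1.8-fold lower number from compound 1 to compound 4 (0.26 log units; within the scatter). Exchanging the 2,6-dichlorobenzyl group for this group, which brings a double bond outside aromatic rings and a hydrogen-bond donor, gives a 1.2-fold lower number from compound 2 to compound 4 (0.07 log units; within the scatter), so compounds 1, 2 and 4 cannot be told apart and this position has yet to show a step beyond the scatter. Only compound 3 stands at a limit: the limit of > 50000 nM in this assay, at which 1 of the 4 values shown sits.

On these data alone, whether a carboxylic acid, a basic amine or a longer alkyl chain on this nitrogen would move the number beyond the scatter remains open. So does the question of what a single change elsewhere on the shared core would do.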